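Aryl replacement at the biaryl end of the amide series

A few compounds are considered here, and "the series" means these few. Any claim that something is new, unique, unknown or untested is made for them only; others in the source may bear on it.

Of the compounds shown here, two have numbers so far. Compound 1 `CCOc1cccc(-c2ccc(CN(C(=O)C3CCCCC3)c3cccc(/C=C/C(=O)OC)c3)cc2)c1` carries a cyclohexyl on the carbonyl carbon; in an assay on isolated protein with Bile acid receptor (Homo sapiens) as the target (on this read-out lower numbers stand for an effect already at smaller amounts and higher numbers for an effect only at larger amounts of compound), compound 1 gives 147 nM. Compound 2 `CCOc1cccc(-c2ccc(CN(C(=O)C(C)C)c3cccc(/C=C/C(=O)OC)c3)cc2)c1` carries an isopropyl there instead; in this assay compound 2 gives 173 nM. Within the data shown here, the single measured step, a 1.2-fold higher number from compound 1 to compound 2 (0.07 log units; within the scatter), shows that swapping the group on the carbonyl carbon leaves the read-out essentially unchanged. Compound 1 stands with the lower of the two numbers, but within the scatter of compound 2, so no order between them can be claimed.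

Compound 3 `COC(=O)/C=C/c1cccc(N(Cc2ccc(-c3ccc(C(C)(C)C)cc3)cc2)C(=O)C2CCCCC2)c1` keeps the cyclohexyl amide of compound 1 and alters the distal aromatic ring: 4-(tert-butyl)phenyl in place of 3-ethoxyphenyl on an aromatic carbon. Among the measured compounds shown here, no measured step touches this ring; the only step available concerns the carbonyl substituent and is within the scatter, so it gives no direct guidance. With nothing to anchor a direction, the expectation for compound 3 is a number close to that of compound 1 with a wide spread, an expected step of a 1.4-fold higher number from compound 1 to compound 3 (0.13 log units; within the scatter). For compound 3 the estimated value in this assay is 200 nM, expected to lie between 60 nM and 700 nM.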

Compound 3, half-maximal effective concentration: 132 nM
Compound 3: the middle estimate sits 1.5-fold (0.18 log units) above what was measured; the range from low to high includes it.
By their numbers in this assay, from the lowest: compounds 3, 1 and 2 (each within the scatter of the next).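

In this assay, 4-(tert-butyl)phenyl in place of 3-ethoxyphenyl on an aromatic carbon gives a 1.1-fold lower number from compound 1 to compound 3 (0.05 log units; within the scatter). Among these compounds, the earlier step concerned only the group on the carbonyl carbon, so this is the first reading at the distal aromatic ring: here the group that leaves carries one hydrogen-bond acceptor and the group that enters carries none, and the read-out shows no change beyond the scatter. No measured information on the cause of this outcome is available for this result.

Among the compounds shown here, the single step exchanges the ethoxy group for tert-butyl and also alters where the substituent stands on the ring, so the contribution of each remains inseparable, and whether the same exchange behaves alike on the isopropyl amide of compound 2 stays unknown. Also open, on these data alone, is how far this ring position tolerates change, since the two groups compared are both substituted phenyl rings carrying no charge, and an unsubstituted phenyl, or a carboxylic acid or an amine on that ring, could show whether the read-out moves at all.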